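Chloro for fluoro: from compound 2 to compound 4

The source may hold more compounds than are shown below. What is called first, only, known or untested is meant among the compounds shown, and "the series" means these compounds.

Three compounds of this series have been run in an assay on isolated protein for inhibition of Amine oxidase [flavin-containing] B (Homo sapiens), read by fluorescence and spectrophotometry; on this read-out higher numbers stand for weaker inhibition and lower numbers for stronger inhibition. Compound 1 `O=C(NCc1cnnn1Cc1ccc2oc(-c3ccc(Cl)cc3)cc(=O)c2c1)c1ccccc1` gives 32900 nM, compound 2 `O=C(CCc1cn(Cc2ccc3oc(-c4ccccc4)cc(=O)c3c2)nn1)Nc1ccc(F)cc1` gives 15600 nM, and compound 3 `Cc1ccc(NC(=O)CCCCc2cn(Cc3ccc4oc(-c5ccc(Cl)cc5)cc(=O)c4c3)nn2)cc1` gives 32900 nM. Compound 2 stands lowest of the three, and both other values lie beyond the scatter from it. Compound 4 `O=C(CCc1cn(Cc2ccc3oc(-c4ccccc4)cc(=O)c3c2)nn1)Nc1ccc(Cl)cc1` is not yet measured; it differs from compound 2 by chloro in place of fluoro on an aromatic carbon. Among the measured compounds shown here, no measured pair in the set isolates this change, so there is nothing here to size it. The expectation is a step of a 1.2-fold lower number from compound 2 to compound 4 (0.08 log units; within the scatter) that stays within the scatter, in either direction. Compound 4 is estimated at 13000 nM, within a range from 5000 nM to 35000 nM.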

Compound 4, half-maximal inhibitory concentration: 15600 nM
Estimate against measurement, compound 4: 1.2-fold (0.08 log units) below; measured number inside the range.
By their numbers in this assay, from the lowest: compounds 2 and 4 (each within the scatter of the next); then compounds 1 and 3 (each within the scatter of the next).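

In this assay, among the compounds shown here, this is the first measured pair that isolates a single change. Replacing (4-fluorophenyl)carbamoyl with (4-chlorophenyl)carbamoyl gives no change at the digits printed from compound 2 to compound 4 (within the scatter), so this read-out does not separate fluoro and chloro at this position, para to a large group. No available evidence accounts for the two halogens reading alike. Still open, from the compounds shown here alone, is whether a different group here, such as methoxy, an amine or a carboxylic acid, would shift the number beyond the scatter.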